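Ethoxy in place of propyl on a short chain

The compounds below may be only part of what the source reports. "The series", "measured", "known", "first", "only" and "open" are said of these compounds alone.

Measured in a functional assay on L1210 cells (Mus musculus) for inhibition, with a stated time of 3 h; a lower number here means that less compound is needed, a higher number that more compound is needed for the effect:
Compound 1 `CCCCCCCCCCCCCCCC(=O)NCC(=O)N[C@@H]1[C@@H](O)[C@H](O)[C@@H](Nc2ncnc3[nH]cnc23)O[C@H]1CO`: 1.6 uM
Compound 2 `CCCCCC(=O)NCC(=O)N[C@@H]1[C@@H](O)[C@H](O)[C@@H](Nc2ncnc3[nH]cnc23)O[C@H]1C`: > 1000 uM

Of these two compounds, only compound 1 has a true number, 1.6 uM. Compound 2 gives > 1000 uM, which is a limit of the assay and not a number. The two compounds differ in more than one place, so their gap cannot be pinned on any single change.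

The next compound, compound 3 `CCOCCC(=O)NCC(=O)N[C@@H]1[C@@H](O)[C@H](O)[C@@H](Nc2ncnc3[nH]cnc23)O[C@H]1C`, keeps the rest of compound 2 and changes one piece of its chain. It carries ethoxy in place of propyl on a saturated chain carbon, two bonds along the chain from a carbonyl carbon. Among the compounds with values here, no measured pair yet shows what a swap of this kind does. The expectation in this assay is therefore modest: no change beyond the scatter, in either direction. The expected step is a number no higher from compound 2 to compound 3 (the limit leaves the size open). For compound 3 the estimated value is 1000 uM, with an expected range of 300 uM to 3000 uM.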

Compound 3, concentration for half-maximal effect: > 1000 uM
Compound 3: a limit, no number (the forecaster's own chance of this, stated with the estimate: 75%); the middle value sits exactly at the limit.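

In this assay compound 3 stands at a limit, not a number (> 1000 uM). Compound 2 also stands at a limit (> 1000 uM). Within the data shown here, no step can therefore be read between compound 2 and compound 3: the limit of > 1000 uM in this assay, at which 2 of the 3 values shown sit. The compounds shown leave open whether ethoxy in place of propyl changes the effect at all.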